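A few compounds are considered here, and "the series" means these few. Any claim that something is new, unique, unknown or untested is made for them only; others in the source may bear on it.

Of the compounds shown here, three have been read so far in an ADME assay on HEp-2 cells (Homo sapiens) for cytotoxicity, read by MTT assay, with a stated time of 72 h (a higher number here means a weaker inhibitor, a lower number a stronger inhibitor), and none of the readings is an exact number. Compound 1 `COc1ccc(C2=C(c3cc(OC)c(OC)c(OC)c3)C(=O)C(O)C2)cc1NC(=O)c1ccccc1` gives > 100 ug/mL, which is a limit of the assay. This puts compound 1 at the high-number end of the data, on (the limit of > 100 ug/mL in this assay, at which 2 of the 3 values shown sit). Compound 3 `CC(=O)OC1C/C(=N/O)C(c2ccccc2)=C1c1ccccc1` gives > 100 ug/mL, also a limit. Compound 2 `COc1ccc(C2=C(c3cc(OC)c(OC)c(OC)c3)C(=O)CC2O)cc1O` gives < 1 ug/mL, again a limit, and it stands at the opposite end, on (the limit of < 1 ug/mL in this assay, at which 1 of the 3 values shown sits).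

Compound 4 `COc1ccc(C2=C(c3cc(OC)c(OC)c(OC)c3)C(=O)C(O)C2)cc1OC(C)C` has not been measured. It differs from compound 1 in one place, with isopropoxy in place of benzamido on an aromatic carbon, ortho to a methoxy group (isopropoxy in place of benzamido on an aromatic carbon). Going by the values given here, no measured pair shows what such an exchange does, so the size of the step is uncertain. A move towards stronger inhibition, beyond the usual scatter, is still expected. That expectation leans on compound 2, whose limit of < 1 ug/mL shows that low readings occur among these compounds. The estimated step is an at least 5.0-fold lower number from compound 1 to compound 4 (0.69 log units; beyond the scatter). Another reading that is only a limit would not be a surprise. For compound 4 the expected value is 20 ug/mL, with an estimated range of 3 ug/mL to 100 ug/mL.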

Compound 4, half-maximal inhibitory concentration: > 100 ug/mL
Compound 4: no number, only a limit; the forecaster's own chance of this, stated with the estimate: 40%; at least 5.0-fold (0.69 log units) between middle value and limit.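

Compound 1 and compound 4 both give only a limit in this assay, not a number, so no step can be read for the exchange of benzamido for isopropoxy. The compounds shown leave open how far past that limit either compound lies, and whether this exchange changes the reading at all.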